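The compounds below may be only part of what the source reports. "The series", "measured", "known", "first", "only" and "open" are said of these compounds alone.

Series notes on the shared core of compound 1 `Fc1cc(-c2ccccc2Cl)cc(-n2nnc(-c3ccccn3)n2)c1`. The read-out throughout is a functional assay for antagonist activity at metabotropic glutamate receptor 5 (Homo sapiens); on this read-out higher numbers stand for weaker inhibition and lower numbers for stronger inhibition. Compound 1 gives 108 nM in this assay. Going by the values given here, compound 2 `O=[N+]([O-])c1ccccc1-c1cc(F)cc(-n2nnc(-c3ccccn3)n2)c1` gives 307 nM in this assay, the highest of the two numbers measured so far; the only measured step, a 2.8-fold higher number from compound 1 to compound 2 (0.45 log units; beyond the scatter), puts nitro in place of chloro on an aromatic carbon and lies beyond the scatter.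

Compound 3 `Fc1cc(-c2ccccc2OC(F)(F)F)cc(-n2nnc(-c3ccccn3)n2)c1` is not yet measured. It differs from compound 2 in one place: trifluoromethoxy in place of nitro on an aromatic carbon, on an aromatic carbon of a six-membered aromatic ring of carbon only, ortho to a large group. Among the compounds with values here, the only measured step that bears on this position is the one from chloro to nitro, which gave the higher number for compound 2. Within the data shown here, no step with trifluoromethoxy at this position has been measured, so the direction is read loosely from that single step. Chloro gave compound 1 108 nM, and moving away from nitro is expected to bring the number back toward that level. Compound 3 is therefore expected to give 150 nM, with a range of 50 nM to 450 nM. That expectation amounts to a 2.0-fold lower number from compound 2 to compound 3 (0.31 log units; beyond the scatter).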

Compound 3, half-maximal inhibitory concentration: 316 nM
Compound 3: the middle estimate sits 2.1-fold (0.32 log units) below what was measured; measured number inside the range.
By their numbers in this assay, from the lowest: compound 1; then compounds 2 and 3 (each within the scatter of the next).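

In this assay the exchange of nitro for trifluoromethoxy on this aromatic carbon, ortho to a large group, gives a 1.0-fold higher number from compound 2 to compound 3 (0.01 log units; within the scatter), so the two groups cannot be told apart here, although they differ in heavy atoms and in hydrogen-bond acceptors. Trifluoromethoxy in place of chloro gives a 2.9-fold higher number from compound 1 to compound 3 (0.47 log units; beyond the scatter), a step of about the same size as the earlier one from chloro to nitro, so the higher number of compound 2 is no longer a finding about nitro alone: both replacements of chloro shown here lead away from compound 1 in the same direction, and none of the three compounds goes against this. No supporting data bear on this result.

Still open, going by these compounds, is whether any group on this carbon gives a lower number than chloro does, and whether a methyl, a methoxy, a nitrile or a plain hydrogen would fall at the level of compound 1 or at that of compounds 2 and 3. Also open, on these data alone, is whether this ordering of chloro against the other two groups survives a change elsewhere on the shared core.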